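A few compounds are considered here, and "the series" means these few. Any claim that something is new, unique, unknown or untested is made for them only; others in the source may bear on it.

- Compound 1 (`Fc1ccc(Nc2nncc3ccccc23)cc1`): 4.5 nM
- Compound 2 (`NS(=O)(=O)c1ccc(Nc2nncc3ccccc23)cc1`): 33 nM

In a functional assay on SF-268 cells (Homo sapiens) for antiproliferative activity, read by sulforhodamine B assay, with a stated time of 72 h (a lower number here means a stronger inhibitor, a higher number a weaker inhibitor), compound 2 stands at 33 nM as the higher of the two numbers, while compound 1 gives 4.5 nM as the lower. Compound 3 (`N#Cc1ccc(Nc2nncc3ccccc23)cc1`) has cyano in place of sulfamoyl on an aromatic carbon, para to a large group (cyano in place of sulfamoyl on an aromatic carbon). Within the data shown here, only one measured step bears on this change: a 7.3-fold higher number from compound 1 to compound 2 (0.87 log units; beyond the scatter) (modest), with sulfamoyl in place of fluoro on an aromatic carbon. Among the measured compounds shown here, no measured compound carries cyano, so that step indicates a direction better than a size. For the measured compounds named here, on the evidence of compound 2 in a 7.3-fold higher number from compound 1 to compound 2 (0.87 log units; beyond the scatter) (its only step), a move toward a lower number in this assay is expected, probably smaller than that step. The expected change is a 2.8-fold lower number from compound 2 to compound 3 (0.44 log units; beyond the scatter) (an estimate). Compound 3 is estimated at 12 nM with an expected range from 3 nM to 45 nM (both estimated).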

Compound 3, half-maximal inhibitory concentration: 3.3 nM
Compound 3: middle estimate off by 3.6-fold (0.56 log units), on the high side; the measured number falls inside the stated range.
By their numbers in this assay, from the lowest: compounds 3 and 1 (each within the scatter of the next); then compound 2.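

At the aromatic carbon para to a large group, the loss seen with sulfamoyl in this assay proves specific to that group rather than common to replacements of fluoro: cyano in place of sulfamoyl gives a 10-fold lower number from compound 2 to compound 3 (1.00 log units; beyond the scatter) and brings the number back into the range of compound 1. Fluoro and cyano cannot be told apart at this place, since the comparison gives a 1.4-fold lower number from compound 1 to compound 3 (0.13 log units; within the scatter) and so shows no real difference. No measurement here explains why sulfamoyl stands apart from the other two groups.

As far as these compounds go, it remains open whether an amine, a carboxylic acid or a methoxy group at this carbon would stay with fluoro and cyano or fall with sulfamoyl. A methylsulfonyl group, which would keep the sulfur and both oxygens but drop the nitrogen, also remains untested among the compounds shown.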